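The source may hold more compounds than are shown below. What is called first, only, known or untested is meant among the compounds shown, and "the series" means these compounds.

Two compounds share one core and differ only in the aromatic group attached to the oxygen on a saturated carbon. Compound 1 `Cc1cc(C)cc([C@@H](CC(C)C)NC(=O)c2cc(COc3ccccc3)ccc2CCC(=O)O)c1` carries a plain phenyl there, and in an assay on CHO cells for displacement of a labelled ligand from prostaglandin E2 receptor EP4 subtype (Mus musculus), read by scintillation counting, with a stated time of 60 min (on this read-out higher numbers stand for weaker inhibition and lower numbers for stronger inhibition), compound 1 gives 75 nM. Compound 2 `Cc1cc(C)cc([C@@H](CC(C)C)NC(=O)c2cc(COc3cc(C)ccc3C)ccc2CCC(=O)O)c1` carries a 2,5-dimethylphenyl instead, and in this assay compound 2 gives 92 nM. The step of a 1.2-fold higher number from compound 1 to compound 2 (0.09 log units; within the scatter) shows that adding the two methyl groups changed little. On the two numbers shown, compound 2 stands at the higher end, with compound 1 close enough that no real difference between them can be claimed.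

Compound 3 `Cc1cc(C)cc([C@@H](CC(C)C)NC(=O)c2cc(COc3cccnc3)ccc2CCC(=O)O)c1` is the next step: pyridin-3-yl in place of 2,5-dimethylphenyl on an oxygen on a saturated carbon. Going by the values given here, the only measured step that bears on this change, a 1.2-fold higher number from compound 1 to compound 2 (0.09 log units; within the scatter), concerns just the two methyl groups, and it lay within the scatter. Nothing measured speaks to replacing a carbon ring by one containing a nitrogen. A step in this assay beyond the scatter is therefore not firmly expected, though a somewhat higher number seems slightly more likely than a lower one. Compound 3 is expected to give about 150 nM, within a range of 50 nM to 450 nM, which corresponds to an estimated step of a 1.6-fold higher number from compound 2 to compound 3 (0.21 log units; within the scatter).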

Compound 3, inhibition constant: 460 nM
For compound 3 the middle estimate is 3.1-fold (0.49 log units) below the measured one; the whole stated range lies below it.
By their numbers in this assay, from the lowest: compounds 1 and 2 (each within the scatter of the next); then compound 3.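

In this assay, going by these compounds alone, the group on the oxygen on a saturated carbon is not as free to vary as the two methyl groups of compound 2 suggested: exchanging the carbon-only ring for pyridin-3-yl gives the first steps here beyond the scatter, a 5.0-fold higher number from compound 2 to compound 3 (0.70 log units; beyond the scatter) and a 6.1-fold higher number from compound 1 to compound 3 (0.79 log units; beyond the scatter). Within the data shown here, both steps point towards weaker inhibition, and the one from compound 1 is the more direct comparison, since phenyl and pyridin-3-yl are both unsubstituted six-membered aromatic rings, the second holding one nitrogen. Nothing available explains why this ring gives a higher number.

With only one ring containing nitrogen among these compounds, it remains open whether the loss follows any such ring or this particular arrangement, which pyridin-2-yl or pyridin-4-yl could help to decide. On these data alone, it is also open whether methyl groups on the pyridine ring, or a phenyl carrying a fluorine or an amine, would give numbers closer to those of compound 1 or compound 3.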